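Pyrimidinyl Piperazine Variant of a Succinimide Anticonvulsant

A few compounds are considered here, and "the series" means these few. Any claim that something is new, unique, unknown or untested is made for them only; others in the source may bear on it.

The series shares a core in which a succinimide bearing a methyl and a phenyl group is linked through an acetyl bridge to an arylpiperazine. Compound 1 `Cc1cccc(N2CCN(C(=O)CN3C(=O)CC(C)(c4ccccc4)C3=O)CC2)c1` and compound 2 `CC1(c2ccccc2)CC(=O)N(CC(=O)N2CCN(c3cccc(Cl)c3)CC2)C1=O` were both tested in a functional assay on the whole organism (strain CD-1) with Mus musculus as the target, in the maximal electroshock model, with a stated time of 2 h; on this read-out higher numbers stand for an effect only at larger amounts of compound and lower numbers for an effect already at smaller amounts; compound 1 gives 300 mg/kg and compound 2 gives 300 mg/kg, and the step of no change at the digits printed from compound 1 to compound 2 (within the scatter) lies within the scatter. Compound 3 `CC1(c2ccccc2)CC(=O)N(CC(=O)N2CCN(c3ccccc3Cl)CC2)C1=O` was reported in this assay as "not active" (no number reported), so no number stands for it. Compound 4 `CC1(c2ccccc2)CC(=O)N(CC(=O)N2CCN(c3ncccn3)CC2)C1=O` has not yet been measured; it differs from compound 3 by pyrimidin-2-yl in place of 2-chlorophenyl on an amine nitrogen in a ring. Within the data shown here, no measured step bears directly on this change, and the only measured step, no change at the digits printed from compound 1 to compound 2 (within the scatter), concerns a different aromatic substituent and was flat. Since compound 3 itself gave no number, the direction of the change cannot be read from the data; compound 4 is expected, on the basis of compound 1 and compound 2, to give 300 mg/kg in this assay, within 100 mg/kg to 1000 mg/kg, with a real chance that only inactivity is reported.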

Compound 4, minimum effective dose: "not active" (no number reported)
No number was reported for compound 4; there is nothing to compare the estimate with.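

In this assay compound 3 gives "not active" (no number reported) and compound 4 gives "not active" (no number reported), so no step can be read between them. The compounds shown leave open how pyrimidin-2-yl and 2-chlorophenyl compare on the amine nitrogen. Nothing shown bears on this result.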